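Styryl Series: Effect of Removing the Cyano Group

The source may hold more compounds than are shown below. What is called first, only, known or untested is meant among the compounds shown, and "the series" means these compounds.

Compound 1 `N#Cc1ccc(/C=C2\CCCN=C2c2cccnc2)cc1` holds the higher of the two numbers obtained so far in an assay on membranes from brain for displacement of a labelled ligand from Neuronal acetylcholine receptor; alpha4/beta2 (Rattus norvegicus), with a stated time of 3 h (on this read-out lower numbers stand for stronger inhibition and higher numbers for weaker inhibition), where compound 1 gives 1230 nM. Compound 2 `C(=C1\CCCN=C1c1cccnc1)\c1ccc2c(c1)OCCO2` gives 520 nM in this assay, a lower number that lies beyond the scatter. Compound 3 `C(=C1\CCCN=C1c1cccnc1)\c1ccccc1` remains unmeasured; it differs from compound 1 thus: hydrogen in place of cyano on an aromatic carbon. Within the data shown here, no measured pair shows this change directly. A move to a lower number is expected for compound 3 because compound 2 without a cyano group gives 520 nM. The estimate for compound 3 is 600 nM, within 200 nM to 2000 nM. The expected step of a 2.1-fold lower number from compound 1 to compound 3 (0.31 log units; beyond the scatter) is near the edge of the scatter.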

Compound 3, inhibition constant: 850 nM
For compound 3 the middle estimate is 1.4-fold (0.15 log units) below the measured one; the range from low to high includes it.
By their numbers in this assay, from the lowest: compounds 2, 3 and 1 (each within the scatter of the next, the first and the last beyond it).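

In this assay, hydrogen in place of cyano on an aromatic carbon para to a large group gives a 1.4-fold lower number from compound 1 to compound 3 (0.16 log units; within the scatter) and leaves the two compounds indistinguishable, so a number of this size does not depend on the nitrile at this position. No measurement available here bears on the reason for this result. From the compounds shown here alone, whether an amine, a carboxylic acid or a methoxy group on this carbon would also stay within the scatter remains open. So does whether the same exchange would behave alike on other carbons of this ring.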